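Moving the hydroxy group on the chalcone aryl ring

The source may report more compounds than this note shows. Statements on the series, on what has been measured and on what is new or still open speak of the compounds shown alone.

The series centres on enone-linked aryl pairs measured in a functional assay on RAW264.7 cells (Mus musculus) for inhibition, with a stated time of 4 days; on this read-out lower numbers stand for stronger inhibition and higher numbers for weaker inhibition. Compound 1 `COc1ccc(/C=C/C(=O)c2cccc(N=[N+]=[N-])c2)cc1O` gives 1960 nM in this assay. Compound 2 `COc1cc(/C=C/C(=O)c2cccc(-n3cc(C(C)(C)O)nn3)c2)ccc1O` gives 19800 nM and compound 3 `COc1cc(/C=C/C(=O)c2cccc(-n3cc(-c4ccc(Br)cc4)nn3)c2)ccc1O` gives 19100 nM. On these numbers compound 2 stands highest of the three; its nearest neighbour is compound 3, reached by a 1.0-fold lower number from compound 2 to compound 3 (0.02 log units; within the scatter), while compound 1 lies furthest away, with a number far below that of compound 2.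

Compound 4 `COc1ccc(/C=C/C(=O)c2cccc(-n3cc(C(C)(C)O)nn3)c2)cc1O` has not yet been measured. It differs from compound 2 in one place: 3-hydroxy-4-methoxyphenyl in place of 4-hydroxy-3-methoxyphenyl on a double-bonded chain carbon bound to a double-bonded chain carbon. The two compounds share every atom, joined differently.

Among the measured compounds shown here, no measured step matches this change. For the measured compounds named here, the only step on record, a 1.0-fold lower number from compound 2 to compound 3 (0.02 log units; within the scatter), concerns the group on the triazole and lies within the scatter. Compound 1 shares the 3-hydroxy-4-methoxyphenyl group of compound 4, but it differs from compound 2 in two places at once, so its lower number cannot be assigned to the aryl pattern alone. Compound 4 is therefore expected to show a 1.3-fold lower number from compound 2 to compound 4 (0.12 log units; within the scatter), with no change beyond the scatter. Compound 4 is estimated at 15000 nM, between 5000 nM and 45000 nM.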

Compound 4, half-maximal inhibitory concentration: 17100 nM
For compound 4 the middle estimate is 1.1-fold (0.06 log units) below the measured one, and the stated range covers the measured number.
By their numbers in this assay, from the lowest: compound 1; then compounds 4, 3 and 2 (each within the scatter of the next).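

With the 3-hydroxy-4-methoxyphenyl group in place of 4-hydroxy-3-methoxyphenyl, this assay gives a 1.2-fold lower number from compound 2 to compound 4 (0.06 log units; within the scatter) and so shows no effect of exchanging the hydroxy and methoxy groups on this aryl ring, at least while the 4-(1-hydroxy-1-methylethyl)-1H-1,2,3-triazol-1-yl group is present. Compound 4 also separates the two changes that compound 1 and compound 2 combine: an 8.7-fold higher number from compound 1 to compound 4 (0.94 log units; beyond the scatter) arises with the 3-hydroxy-4-methoxyphenyl group held constant and only azido replaced on the aromatic carbon, so that replacement alone is enough to give a difference beyond the scatter. No evidence on hand gives a reason for either outcome.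

The compounds shown leave open whether the hydroxy and methoxy exchange would remain without effect alongside azido or 4-bromophenyl, since each of these groups appears with only one of the two aryl patterns. They also leave open whether an amine or a carboxylic acid in place of 1-hydroxy-1-methylethyl on the triazole would bring the number back towards that of compound 1.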